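Removing One Bromine Atom: Expected Effect on Cytotoxicity

The source may hold more compounds than are shown below. What is called first, only, known or untested is meant among the compounds shown, and "the series" means these compounds.

Among the compounds with values here, compound 1 `CNC(=O)c1cc(Oc2ccc(C3=NNC(c4cccc(Br)c4)C3)cc2)ccn1` is the only compound in this set with a number attached: in a functional assay on MCF7 cells (Homo sapiens) for cytotoxicity, read by MTT assay, with a stated time of 72 h (a lower number here means a stronger inhibitor, a higher number a weaker inhibitor), compound 1 gives 1960 nM. A second analogue, compound 2 `CNC(=O)c1cc(Oc2ccc(C3=NNC(c4ccc(F)cc4Cl)C3)cc2)ccn1`, was prepared, but in this assay compound 2 gives "not determined" (no result reported), so it offers no point of comparison. Compound 3 `CNC(=O)c1cc(Oc2ccc(C3=NNC(c4ccccc4)C3)cc2)ccn1` is the next member to be measured. The structural change from compound 1 to compound 3 is small: hydrogen in place of bromo on an aromatic carbon. Within the data shown here, no step between two measured compounds exists to calibrate what such a change does here, so the expectation rests on the single value of compound 1 alone. The step of a 1.8-fold higher number from compound 1 to compound 3 (0.25 log units; within the scatter) is expected to be a modest weakening, lying near the edge of the usual scatter rather than far beyond it. Compound 3 is therefore estimated at 3500 nM, with a likely range from 1200 nM to 10000 nM.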

Compound 3, half-maximal inhibitory concentration: 1240 nM
Estimate against measurement, compound 3: 2.8-fold (0.45 log units) above; measured number inside the range.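

In this assay, within the data shown here, the swap of bromo for hydrogen gives the first calibrated step at this position (a 1.6-fold lower number from compound 1 to compound 3 (0.20 log units; within the scatter)), and the printed scatter covers that step. The two compounds therefore cannot be told apart here, which shows that the bromine atom on this aromatic carbon is not needed for cytotoxicity at this level, and that the plain phenyl serves as well as the 3-bromophenyl. Nothing on hand explains this outcome.

From the compounds shown here alone, whether an amine, a carboxylic acid or a methoxy group on this same aromatic carbon would move the number beyond the scatter remains open, since bromo and hydrogen are the only two substituents compared here. Any step involving compound 2 cannot be read, so the effect of its fluoro and chloro substituents also remains unknown.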